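A few compounds are considered here, and "the series" means these few. Any claim that something is new, unique, unknown or untested is made for them only; others in the source may bear on it.

Compound 2 `CC1CCN(S(=O)(=O)c2ccc(NC(=O)NCc3cccnc3)cc2)CCN1` gives 11 nM in an assay on isolated protein for inhibition of Nicotinamide phosphoribosyltransferase (Homo sapiens), read by spectrophotometry, with stated times of 15 min and 30 min (a lower number here means a stronger inhibitor, a higher number a weaker inhibitor), the lowest of the two numbers recorded, while compound 1 `O=C(NCc1cccnc1)Nc1ccc(S(=O)(=O)N2CCCNCC2)cc1` gives 45 nM. Within the data shown here, the only measured step, a 4.1-fold lower number from compound 1 to compound 2 (0.61 log units; beyond the scatter), concerns a methyl on a saturated ring carbon and does not touch the change now considered. Compound 3 `O=C(NCc1cccnc1)Nc1ccc(S(=O)(=O)N[C@H]2CC[C@H](O)CC2)cc1` differs from compound 2 by a group of 8 heavy atoms (6 carbon, 1 nitrogen, 1 oxygen; one six-membered non-aromatic ring of carbon only) in place of a group of 8 heavy atoms (6 carbon, 2 nitrogen; one seven-membered non-aromatic ring with 2 hetero atoms), on a sulfonyl sulfur. Among the measured compounds shown here, no measured step bears on this exchange, so its direction is uncertain. For compound 3 a modest step of a 2.7-fold higher number from compound 2 to compound 3 (0.44 log units; beyond the scatter) toward a higher number is expected. Compound 3 is estimated at 30 nM, with a range of 8 nM to 150 nM.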

Compound 3, half-maximal inhibitory concentration: 8 nM
Compound 3: the middle estimate sits 3.8-fold (0.57 log units) above what was measured; the range from low to high includes it.
By their numbers in this assay, from the lowest: compounds 3 and 2 (each within the scatter of the next); then compound 1.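

On the sulfonyl sulfur, (4-hydroxycyclohexyl)amino stands in for the seven-membered ring of compound 2 without a change beyond the scatter in this assay (a 1.4-fold lower number from compound 2 to compound 3 (0.14 log units; within the scatter)). Against the 1,4-diazepan-1-yl of compound 1, the same group gives a 5.6-fold lower number from compound 1 to compound 3 (0.75 log units; beyond the scatter), so among these compounds a ring with two hetero atoms is not needed at this position. No evidence accompanies this result to explain it. Open, going by these compounds, is what the hydroxyl contributes: an amine or a methoxy group in its place on the cyclohexane ring, or a plain cyclohexylamino group, would address that.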